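This account rests on a few compounds, and the source may have more. Where it says the series, first, only, none or still open, it means among the compounds named here.

Working notes on the series: two compounds so far have numbers in an ADME assay on microsomes (Mus musculus) for metabolic stability; a lower number here means slower removal, a higher number faster removal of the compound. Compound 1 (`CNC(=O)[C@@H]1CCCN1S(=O)(=O)c1ccc(Cl)c(COc2cccc3c(OCc4ccccc4)cc(C)nc23)c1Cl`) gives 1820 mL/min/kg in this test, while compound 2 (`CNC(=O)[C@@H]1CCCN1S(=O)(=O)c1ccc(Cl)c(COc2cccc3c(-c4ccncc4)cc(C(C)C)nc23)c1Cl`) gives 633 mL/min/kg as the lower of the two numbers, a gap beyond the scatter. Compound 3 (`CNC(=O)[C@@H]1CCCN1S(=O)(=O)c1ccc(Cl)c(COc2cccc3c(OCc4ccccc4)cc(C(C)C)nc23)c1Cl`) keeps the isopropyl group of compound 2 but has benzyloxy in place of pyridin-4-yl on an aromatic carbon, opposite the ring nitrogen (benzyloxy in place of pyridin-4-yl on an aromatic carbon). Among the compounds with values here, no measured pair isolates this change, so the size of the step remains a judgement. Within the data shown here, the only guide is compound 1, which also carries benzyloxy and stands at 1820 mL/min/kg despite differing elsewhere. A rise is therefore expected, with the estimated step of a 2.4-fold higher number from compound 2 to compound 3 (0.37 log units; beyond the scatter) in this assay likely to lie beyond the scatter. For compound 3 the expected clearance is 1500 mL/min/kg as the central estimate, within an estimated range of 800 mL/min/kg to 2700 mL/min/kg overall.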

Compound 3, clearance: 1220 mL/min/kg
Beside the measured number, compound 3's estimate is 1.2-fold (0.09 log units) above it; the range from low to high includes it.
By their numbers in this assay, from the lowest: compounds 2, 3 and 1 (each within the scatter of the next, the first and the last beyond it).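

In this assay, benzyloxy in place of pyridin-4-yl on an aromatic carbon, opposite the ring nitrogen, can now be read with the isopropyl group held constant (a 1.9-fold higher number from compound 2 to compound 3 (0.28 log units; within the scatter)), so this exchange alone is not resolved from repeat-measurement variation. Isopropyl in place of methyl on an aromatic carbon, read with benzyloxy held constant (a 1.5-fold lower number from compound 1 to compound 3 (0.17 log units; within the scatter)), is likewise not resolved, and compound 3 thus provides the first single-place steps in the series. No supporting data bear on what lies behind either step.

Still open, on these data alone, is whether an amine or a carboxylic acid in place of benzyloxy, opposite the ring nitrogen, would give a step beyond the scatter. A longer chain in place of isopropyl also remains to be placed against compound 3 in this assay as a single-place change.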